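Hydroxy to anilino in a level cytotoxicity series

The source may hold more compounds than are shown below. What is called first, only, known or untested is meant among the compounds shown, and "the series" means these compounds.

Three compounds have numbers in an ADME assay on HepG2 cells (Homo sapiens) for cytotoxicity, read by CellTiter-Glo, with a stated time of 72 h; a lower number here means that less compound is needed, a higher number that more compound is needed for the effect. Compound 1 (`C/C1=C/[C@]23O[C@H]2[C@H](C)C=C3C(=O)[C@@](C)(O)C(=O)CC(C)(C)/C=C/C1=O`) gives 26000 nM, compound 2 (`CC1=C2CC(C)(C)/C(c3ccc(C(F)(F)F)cc3)=C/C(=O)/C(C)=C\C3=C[C@H](C)C[C@]3(O2)C1=O`) gives 26000 nM, and compound 3 (`C/C1=C/C2=C[C@H](C)C[C@@]23O[C@]2(CC(C)(C)[C@@H](O)[C@@H]2C1=O)[C@@H](C)C3=O`) gives 26000 nM. Compound 3 therefore stands level with the other two. The three structures differ in more than one place, yet their values coincide at the digits shown, so the numbers offer no ordering and no trend to extend.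

The next compound is compound 4 (`C/C1=C/C2=C[C@H](C)C[C@@]23O[C@]2(CC(C)(C)[C@@H](Nc4ccccc4)[C@@H]2C1=O)[C@@H](C)C3=O`), which carries anilino in place of hydroxy on a saturated ring carbon. The site lies on a five-membered non-aromatic ring of carbon only, part of a fused or bridged system of four rings.

For the measured compounds named here, no measured pair isolates this change, so any expectation rests on thin ground. Compound 2, which also carries an aromatic ring, gives 26000 nM in this assay, and that value offers no sign that an aromatic ring alone separates a compound from the others. The expected 1.2-fold lower number from compound 3 to compound 4 (0.07 log units; within the scatter) stays within the scatter, and any larger move is expected toward a lower number. For compound 4 the estimate is 22000 nM, with an expected range of 8000 nM to 32000 nM.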

Compound 4, half-maximal effective concentration: 26000 nM
Estimate against measurement, compound 4: 1.2-fold (0.07 log units) below, and the stated range covers the measured number.
By their numbers in this assay, from the lowest: compounds 1, 2, 3 and 4 (each within the scatter of the next).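

In this assay, for the compounds shown here, anilino in place of hydroxy on a saturated ring carbon gives no change at the digits printed from compound 3 to compound 4 (within the scatter), and this is the first step that isolates a change in one place. The position, on a five-membered non-aromatic ring of carbon only, therefore accepts the larger anilino group with its six-membered aromatic ring of carbon only, with no readable shift in this read-out; the counts of hydrogen-bond donors and acceptors are the same for the group that leaves and the group that enters. No measurement available here speaks to why the number stays level, so the step stands as an observation only.

As far as these compounds go, both groups on this carbon carry a hydrogen-bond donor and an acceptor, so the effect of a group such as methoxy, dimethylamino or a carboxylic acid at the same place remains open. From the compounds shown here alone, with compound 4 at 26000 nM, it also remains open whether any substituent on the anilino ring, such as a methoxy or a chlorine, would move the number beyond the scatter in this assay.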